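Fluoro for Methoxy: What to Expect of Compound 4

The source may hold more compounds than are shown below. What is called first, only, known or untested is meant among the compounds shown, and "the series" means these compounds.

Compound 1, `COc1ccc(N(C)C(=O)N(C)c2cc(OC)c(OC)c(OC)c2)cc1`: in a functional assay on Daoy cells (Homo sapiens) for cytotoxicity, read by MTT assay, with a stated time of 72 h (on this read-out higher numbers stand for weaker inhibition and lower numbers for stronger inhibition), compound 1 gives >= 125000 nM, which is a limit of the assay and not a number.
Compound 2, `COc1cc(N(C)C(=O)c2ccc([N+](=O)[O-])cc2)cc(OC)c1OC`: in this assay compound 2 gives >= 125000 nM, also a limit of the assay and not a number.
Compound 3, `COc1cc(NC(=O)c2ccc3ccccc3c2)cc(OC)c1OC`: in this assay compound 3 gives 48700 nM.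

For the measured compounds named here, compound 1 therefore stands at the limit of >= 125000 nM in this assay, at which 2 of the 3 values shown sit; it is one of the two compounds for which no number is reported, while compound 3 is the only one with a measured value, and that value shows only weak inhibition.

Compound 4, `COc1cc(N(C)C(=O)N(C)c2ccc(F)cc2)cc(OC)c1OC`, has not yet been measured. It differs from compound 1 in one place: fluoro in place of methoxy on an aromatic carbon.

Going by the values given here, no pair of measured compounds differing in one place is available, so there is no measured step to lean on. Since compound 1 gives >= 125000 nM as a limit, the change is expected to bring no step beyond the usual scatter, with an at least 1.1-fold lower number from compound 1 to compound 4 (0.05 log units; that floor lies within the scatter). Compound 4 is therefore expected to give about 110000 nM in this assay, somewhere between 35000 nM and 300000 nM, and quite possibly only another limit.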

Compound 4, half-maximal inhibitory concentration: >= 125000 nM
Compound 4: a limit, no number; the forecaster's own chance of this, stated with the estimate: 60%; middle value at least 1.1-fold (0.05 log units) from the limit.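

Compound 1 and compound 4 each give only a limit of the assay and no number, so no step can be read between them: the limit of >= 125000 nM in this assay, at which 3 of the 4 values shown sit. The compounds shown leave open whether going from 4-methoxyphenyl to 4-fluorophenyl changes inhibition in this assay at all, and in which direction.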